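Shifting the bromophenyl pattern: what compound 4 may show

This account rests on a few compounds, and the source may have more. Where it says the series, first, only, none or still open, it means among the compounds named here.

Compound 1 `COc1cc(-c2c(C#N)c(N)n(/N=C/c3cn(-c4ccccc4)nc3-c3ccccc3)c(=O)c2C#N)cc(OC)c1OC`: 64 ug/mL
Compound 2 `N#Cc1c(-c2ccccc2[N+](=O)[O-])c(C#N)c(=O)n(/N=C/c2cn(-c3ccccc3)nc2-c2ccccc2)c1N`: > 200 ug/mL, a limit of the assay
Compound 3 `N#Cc1c(-c2ccccc2Br)c(C#N)c(=O)n(/N=C/c2cn(-c3ccccc3)nc2-c2ccccc2)c1N`: 174 ug/mL

In an ADME assay on NIH3T3 cells (Mus musculus) for cytotoxicity, read by MTT assay (a lower number here means a stronger inhibitor, a higher number a weaker inhibitor), compound 3 stands highest of the two numbers; its nearest neighbour is compound 1, with a 2.7-fold higher number from compound 1 to compound 3 (0.43 log units; beyond the scatter). For compound 2 the assay reports only a limit, (the limit of > 200 ug/mL in this assay, at which 1 of the 3 values shown sits). Compound 4 `N#Cc1c(-c2ccc(Br)cc2)c(C#N)c(=O)n(/N=C/c2cn(-c3ccccc3)nc2-c2ccccc2)c1N` differs from compound 3 by 4-bromophenyl in place of 2-bromophenyl on an aromatic carbon. For the measured compounds named here, the only measured step touching a bromo group, an at least 1.1-fold lower number from compound 2 to compound 3 (0.06 log units; that floor lies within the scatter), lies within the scatter, and no measured step moves a group from one ring position to another, so the prior evidence is thin. Compound 4 is therefore expected to show a 1.0-fold lower number from compound 3 to compound 4 (0.01 log units; within the scatter), nothing beyond the scatter. The estimate for compound 4 is 170 ug/mL, with a range from 85 ug/mL to 250 ug/mL.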

Compound 4, half-maximal inhibitory concentration: > 200 ug/mL
Compound 4: only a limit was reported; the forecaster's own chance of this, stated with the estimate: 35%; middle value at least 1.1-fold (0.07 log units) from the limit.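

In this assay, for the compounds shown here, the step of an at least 1.1-fold higher number from compound 3 to compound 4 (0.06 log units; that floor lies within the scatter) gives the first reading of a bromo shift on this aryl group, and its floor does not go beyond the scatter. Replacing the 3,4,5-trimethoxyphenyl group with 4-bromophenyl gives an at least 3.1-fold higher number from compound 1 to compound 4 (0.49 log units; beyond the scatter), the same direction as the steps to the 2-bromophenyl and 2-nitrophenyl groups. Compound 2 and compound 4 sit at one limit, so the step between them cannot be read: the limit of > 200 ug/mL in this assay, at which 2 of the 4 values shown sit.

On these data alone, the true size of the bromo shift stays open. So does the effect of a carboxylic acid or an amine on this phenyl ring.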